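Replacing the phenyl group of compound 3

A few compounds are considered here, and "the series" means these few. Any claim that something is new, unique, unknown or untested is made for them only; others in the source may bear on it.

In a functional assay on FM3A cells (Mus musculus) for cytotoxicity (on this read-out higher numbers stand for an effect only at larger amounts of compound and lower numbers for an effect already at smaller amounts), compound 1 `COOC1(OOC)CCCCCCCCCCC1` gives 1500 nM, compound 2 `C=C(C)COOC1(OOC)CCCCCCCCCCC1` gives 17000 nM and compound 3 `COOC1(OOCCCc2ccccc2)CCCCCCCCCCC1` gives 34000 nM. Compound 3 stands with compound 2 at the upper end of these numbers, the gap between them being a 2.0-fold higher number from compound 2 to compound 3 (0.30 log units; within the scatter). Compound 1 lies well apart from both.

Compound 4 `COOC1(OOCCCCCCOC2CCOCC2)CCCCCCCCCCC1` has not yet been measured. It carries 3-((oxan-4-yl)oxy)propyl in place of phenyl on a saturated chain carbon, three bonds along the chain from an oxygen.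

Within the data shown here, no measured step makes this exact change, so the evidence is indirect. Adding a group to compound 1 gave large steps, namely an 11-fold higher number from compound 1 to compound 2 (1.05 log units; beyond the scatter) and a 23-fold higher number from compound 1 to compound 3 (1.36 log units; beyond the scatter). Those steps add a group to a hydrogen, however, whereas compound 4 exchanges one group for another. Among the measured compounds shown here, the closest precedent is therefore a 2.0-fold higher number from compound 2 to compound 3 (0.30 log units; within the scatter), and on that basis this exchange is also expected to stay within the scatter in this assay, with neither direction clearly favoured. The expected step is a 1.1-fold lower number from compound 3 to compound 4 (0.05 log units; within the scatter). For compound 4 the estimated value is 30000 nM, with an expected range from 10000 nM to 80000 nM.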

Compound 4, half-maximal effective concentration: 7600 nM
Beside the measured number, compound 4's estimate is 3.9-fold (0.60 log units) above it, outside the stated range (below it).
By their numbers in this assay, from the lowest: compound 1; then compound 4; then compounds 2 and 3 (each within the scatter of the next).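

In this assay, among these compounds, the end of this chain proved sensitive to what is placed there: a 4.5-fold lower number from compound 3 to compound 4 (0.65 log units; beyond the scatter), whereas the only earlier exchange of one group for another, a 2.0-fold higher number from compound 2 to compound 3 (0.30 log units; within the scatter), stayed within the scatter. Every step shown before this one that went beyond the scatter added a group to compound 1 and raised the number, as in a 23-fold higher number from compound 1 to compound 3 (1.36 log units; beyond the scatter), so this is the first change shown that moves the number down, here on a saturated chain carbon, three bonds along the chain from an oxygen. No measurement is at hand that would account for this shift.

The change from phenyl to 3-((oxan-4-yl)oxy)propyl alters several things at once, namely the heavy-atom count, the aromatic ring and the hydrogen-bond acceptors, and the compounds shown cannot separate these contributions. As far as these compounds go, it also remains open whether a cyclohexyl group in place of the oxan-4-yl ring, or an amine at the end of the same chain, would move the number in the same direction.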